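A few compounds are considered here, and "the series" means these few. Any claim that something is new, unique, unknown or untested is made for them only; others in the source may bear on it.

Measured in a functional assay on MDA-MB-231 cells (Homo sapiens) for inhibition, read by MTT assay, with a stated time of 72 h; on this read-out higher numbers stand for weaker inhibition and lower numbers for stronger inhibition:
- compound 1 `Cc1ccc(NC(=O)CCCn2cc(-c3ccc(C(F)(F)F)cc3)nn2)cc1`: 2300 nM
- compound 2 `COC(=O)c1ccc(-c2cn(CCCC(=O)Nc3ccc(-c4ccccc4)cc3)nn2)cc1`: > 100000 nM (a limit)

Compound 2 stands at a limit: > 100000 nM in this assay is a limit and not a number.

Compound 3 `O=C(CCCn1cc(-c2ccc(C(F)(F)F)cc2)nn1)Nc1ccc(-c2ccccc2)cc1` follows from compound 2 by trifluoromethyl in place of methoxycarbonyl on an aromatic carbon, para to a large group: trifluoromethyl in place of methoxycarbonyl on an aromatic carbon. Within the data shown here, no measured pair isolates this change. The 4-(trifluoromethyl)phenyl that enters also stands in compound 1, which gives 2300 nM, so a step towards stronger inhibition, beyond the scatter, is expected. A second reading at the limit remains possible. The estimated step is an at least 12-fold lower number from compound 2 to compound 3 (1.09 log units; beyond the scatter). For compound 3 the expected value is 8000 nM, with an estimated range of 1500 nM to 60000 nM.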

Compound 3, half-maximal inhibitory concentration: 2000 nM
Compound 3: the middle estimate sits 4.0-fold (0.60 log units) above what was measured; the measured number falls inside the stated range.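

In this assay, trifluoromethyl in place of methoxycarbonyl on an aromatic carbon, para to a large group, gives an at least 50-fold lower number from compound 2 to compound 3 (1.69 log units; beyond the scatter), so the group at this place decides whether a number can be read at all. Compound 2 is a limit and not a number, so this step has no upper end: the limit of > 100000 nM in this assay, at which 1 of the 3 values shown sits. With 4-(trifluoromethyl)phenyl in place, phenyl in place of methyl on an aromatic carbon gives a 1.2-fold lower number from compound 1 to compound 3 (0.06 log units; within the scatter), so that change does not separate the two compounds in this assay.

Still open, going by these compounds, is whether the gap belongs to methoxycarbonyl alone or extends to other groups at this place, such as a carboxylic acid, a nitrile or an amine. Also open, on these data alone, is whether a longer chain in place of the present one would shift the value.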